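A few compounds are considered here, and "the series" means these few. Any claim that something is new, unique, unknown or untested is made for them only; others in the source may bear on it.

Notes on the purine series. Compound 1 `CCCCCCC(CCO)n1cnc2c(N)ncnc21` carries an amino group and a hydrogen on the six-membered ring. In a functional assay on HCT-116 cells (Homo sapiens) for antiproliferative activity, read by MTT assay, with a stated time of 48 h (a higher number here means a weaker inhibitor, a lower number a stronger inhibitor), compound 1 gives > 50000 nM, which is a limit of the assay and not a number. Compound 2 `CCCCCCC(CCO)n1cnc2c(N)nc(Cl)nc21` differs from compound 1 by chloro in place of hydrogen on an aromatic carbon. In this assay compound 2 gives > 50000 nM, again a limit of the assay. The step that the two limits leave unreadable from compound 1 to compound 2 therefore cannot be read, because the limit of > 50000 nM in this assay, at which 2 of the 3 values shown sit, holds both ends.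

Compound 3 `CCCCCCCCCC(CCO)n1cnc2c(Cl)ncnc21` has a different core; the difference between the cores of compound 1 and compound 3 is not broken down here. In this assay, within the data shown here, compound 3 gives 890 nM, the only number in the set.

Compound 4 `CCCCCCCCCC(CCO)n1cnc2c(Cl)nc(Cl)nc21`, not yet measured, differs from compound 3 by chloro in place of hydrogen on an aromatic carbon. This is the same kind of change as from compound 1 to compound 2, though the place differs: there the new chloro sits meta to an amino group, here meta to a chloro group. Since the earlier step is unreadable, the expected step of a 1.7-fold higher number from compound 3 to compound 4 (0.23 log units; within the scatter) rests only on compound 3 at 890 nM and is kept small. Compound 4 is thus estimated at 1500 nM, in a range of 300 nM to 8000 nM.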

Compound 4, half-maximal inhibitory concentration: 32600 nM
Compound 4: middle estimate off by 22-fold (1.34 log units), on the low side; measured number outside the range, above it.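

In this assay, chloro in place of hydrogen on an aromatic carbon, between two ring nitrogen atoms, gives a 37-fold higher number from compound 3 to compound 4 (1.56 log units; beyond the scatter), so on the core of compound 3 this single change carries a large penalty. Among these compounds, the same change on the core of compound 1 gives no size to compare, and whether the step carries from one core to the other stays unsettled: the limit of > 50000 nM in this assay, at which 2 of the 4 values shown sit. With one readable step, the series shows only that the change can matter on one core; it does not show a rule across cores, and it gives no reason for the size of the step.

Left open is how a fluoro or a methyl group would behave in place of the new chloro of compound 4, which would show whether the step belongs to chloro itself or to any group at that place. Also open, as far as these compounds go, is whether a longer chain than that of compound 3 would change the size of this step.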